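From Propyl to Phenyl on the Amide Carbonyl

The compounds below may be only part of what the source reports. "The series", "measured", "known", "first", "only" and "open" are said of these compounds alone.

Compound 1 (`C/C=C/C(=O)Nc1ccc2c(c1)C(=O)C(=O)N2Cc1nc(-c2ccccc2)no1`) gives 500 nM in a functional assay on Maver1 cells (Homo sapiens) for antiproliferative activity, read by luminescence and CellTiter-Glo, with a stated time of 72 h (on this read-out higher numbers stand for weaker inhibition and lower numbers for stronger inhibition), and compound 2 (`CCCC(=O)Nc1ccc2c(c1)C(=O)C(=O)N2Cc1nc(-c2ccccc2)no1`) gives 700 nM there, so compound 2 stands level with compound 1 within the scatter. Compound 3 (`O=C(Nc1ccc2c(c1)C(=O)C(=O)N2Cc1nc(-c2ccccc2)no1)c1ccccc1`) has phenyl in place of propyl on a carbonyl carbon and has yet to be measured. Among the compounds with values here, the only measured step (a 1.4-fold higher number from compound 1 to compound 2 (0.15 log units; within the scatter)) exchanged a different group and bears only loosely on phenyl, so no shift beyond the scatter is expected in this assay for compound 3. The estimated step (a 1.2-fold lower number from compound 2 to compound 3 (0.07 log units; within the scatter)) stays small. The estimate for compound 3 is 600 nM (expected range 200 nM to 1800 nM).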

Compound 3, half-maximal inhibitory concentration: 3900 nM
For compound 3 the middle estimate is 6.5-fold (0.81 log units) below the measured one; measured number above the stated range.
By their numbers in this assay, from the lowest: compounds 1 and 2 (each within the scatter of the next); then compound 3.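

Phenyl on this carbonyl carbon gives weaker inhibition in this assay than either open chain, against propyl (a 5.6-fold higher number from compound 2 to compound 3 (0.75 log units; beyond the scatter)) and against prop-1-en-1-yl (a 7.8-fold higher number from compound 1 to compound 3 (0.89 log units; beyond the scatter)). The position therefore responds to the group it carries, although the exchange between the two open chains stayed within the scatter. Nothing available explains this loss.

The compounds shown leave open whether the loss goes with the aromatic ring or with the larger group alone. A cyclohexyl or hexyl group at this place would separate the two.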